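Removing One Chloro Group from Compound 1

The source may hold more compounds than are shown below. What is called first, only, known or untested is meant among the compounds shown, and "the series" means these compounds.

Of the compounds shown here, three built on a shared core have been tested in a functional assay on A549 cells (Homo sapiens) for antiproliferative activity, read by MTT assay; on this read-out lower numbers stand for stronger inhibition and higher numbers for weaker inhibition. Compound 1 `COc1ccc(-c2ccnc(Nc3ccc(Cl)cc3Cl)n2)cc1` gives 7330 nM in this assay. Compound 2 `COc1cccc(Nc2nccc(-c3ccc(Br)cc3)n2)c1` gives 82700 nM, and compound 3 `Cc1cccc(Nc2nccc(-c3ccc(Cl)cc3Cl)n2)c1` gives 18500 nM. Among these three numbers compound 1 holds the lowest and therefore stands as the strongest inhibitor of the set: its gap to compound 3 is beyond the usual scatter, and its gap to compound 2 is wider still.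

Compound 4 `COc1ccc(-c2ccnc(Nc3ccc(Cl)cc3)n2)cc1` has not yet been measured. It differs from compound 1 in a single place: hydrogen in place of chloro on an aromatic carbon. Going by the values given here, no measured pair in this set shows the same change, so the size of the step has to be judged from the change itself. Taking away one heavy atom from the ring that carries two chloro groups in compound 1 is expected to weaken inhibition somewhat, giving a modest rise in the number that may sit near the edge of the scatter. The expected step is a 2.0-fold higher number from compound 1 to compound 4 (0.31 log units; beyond the scatter) in this assay. Compound 4 is therefore estimated at 15000 nM, with a likely range from 5000 nM to 45000 nM.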

Compound 4, half-maximal inhibitory concentration: 20900 nM
Estimate against measurement, compound 4: 1.4-fold (0.14 log units) below, within the range that was stated.
By their numbers in this assay, from the lowest: compound 1; then compounds 3 and 4 (each within the scatter of the next); then compound 2.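

In this assay the chloro group that sits ortho to a large group and meta to the other chloro group, when replaced by hydrogen, gives a 2.9-fold higher number from compound 1 to compound 4 (0.46 log units; beyond the scatter) and so weaker inhibition. Going by these compounds alone, this is the first direct reading of a single change in the set: the earlier compounds differ from one another in more than one place, so their numbers could not show what this one chloro group contributes. With everything else in compound 1 held the same, chloro at this position gives stronger inhibition than hydrogen, although the step is modest and no data at hand explain it.

As far as these compounds go, it remains open whether this advantage is particular to chloro or would also appear with another group at the same position, such as fluoro, bromo, methyl or methoxy. From the compounds shown here alone, it is also open how much the remaining chloro group contributes, since a compound with hydrogen in its place and the first chloro group kept would be needed to compare the two positions directly.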